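The source may report more compounds than this note shows. Statements on the series, on what has been measured and on what is new or still open speak of the compounds shown alone.

Measured compounds:
- Compound 1, `COc1ccc(-c2cc(/C=C/C(=O)c3ccc(N)cc3)[nH]n2)cc1`: 1700 nM
- Compound 2, `COc1ccc2c(c1)C/C(=C\c1cc(-c3cc(OC)c(OC)c(OC)c3)n[nH]1)C2=O`: 2000 nM
- Compound 3, `COc1cc(-c2cc(/C=C/C(=O)c3ccc(Cl)c(Cl)c3)[nH]n2)cc(OC)c1OC`: 2100 nM

All three numbers come from a functional assay on MDA-MB-231 cells (Homo sapiens) for inhibition, read by MTT assay, with a stated time of 48 h; on this read-out lower numbers stand for stronger inhibition and higher numbers for weaker inhibition. Compound 3 gives 2100 nM in this assay, and that number is not separated from the numbers of compound 2 or compound 1 by more than the usual scatter of repeated measurements, so the three compounds cannot be told apart on the figures shown.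

Compound 4, `COc1ccc(C(=O)/C=C/c2cc(-c3cc(OC)c(OC)c(OC)c3)n[nH]2)cc1`, has not yet been measured in this assay. It differs from compound 3 in one place: 4-methoxyphenyl in place of 3,4-dichlorophenyl on a carbonyl carbon. Within the data shown here, no pair of measured compounds here differs by a single change, so there is no measured step to lean on, only the observation that the three compounds carrying different groups on the carbonyl carbon all land close together.

On that basis the expected step from compound 3 to compound 4 in this assay is small, a 1.1-fold lower number from compound 3 to compound 4 (0.02 log units; within the scatter), with no direction that can be called beyond the scatter. Compound 4 is therefore estimated at 2000 nM in this assay, with a plausible range from 900 nM to 4500 nM.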

Compound 4, half-maximal inhibitory concentration: 950 nM
Compound 4: the middle estimate sits 2.1-fold (0.32 log units) above what was measured; the range from low to high includes it.
By their numbers in this assay, from the lowest: compounds 4, 1, 2 and 3 (each within the scatter of the next, the first and the last beyond it).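

In this assay, putting 4-methoxyphenyl in place of 3,4-dichlorophenyl on a carbonyl carbon gives a 2.2-fold lower number from compound 3 to compound 4 (0.34 log units; beyond the scatter). Among these compounds, this is the first single change here that can be read, and it shows that the group at this place can shift the number beyond the usual scatter, though only modestly. The two groups have the same heavy-atom count and the same six-membered aromatic ring of carbon only, so the difference lies in two chlorine atoms leaving and a methoxy oxygen, counted as a hydrogen-bond acceptor, entering, but no measurement here explains why the number moves.

This single pair cannot show whether the lower number of compound 4 comes from losing the chlorine atoms, from gaining the methoxy group, or from both together. A plain phenyl group on the same carbonyl carbon would help to separate these two parts of the change, and a nitrile or a carboxylic acid on that ring would show how far the trend extends, if there is one at all.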